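Swapping an Ethoxyphenyl for a Nitrophenyl on the Shared Core

The compounds below may be only part of what the source reports. "The series", "measured", "known", "first", "only" and "open" are said of these compounds alone.

Three compounds share one core and differ only in the group bound to a nitrogen on an aromatic ring. Compound 1 `CCCCCCCCNc1nc(SCc2ccc(C(F)(F)F)cc2)nc2ccccc12` carries an octyl chain there, and in a functional assay on MCF7 cells (Homo sapiens) for cytotoxicity, read by MTT assay, with a stated time of 72 h (a higher number here means a weaker inhibitor, a lower number a stronger inhibitor), compound 1 gives 26100 nM. Compound 2 `COc1ccccc1Nc1nc(SCc2ccc(C(F)(F)F)cc2)nc2ccccc12` carries a 2-methoxyphenyl instead. In this assay compound 2 stops at the assay's limit, > 50000 nM, which is a bound and not a number. Compound 3 `CCOc1ccccc1Nc1nc(SCc2ccc(C(F)(F)F)cc2)nc2ccccc12` carries a 2-ethoxyphenyl. In this assay compound 3 likewise stops at the limit, > 50000 nM, so only a bound is known for it. The steps of an at least 1.9-fold higher number from compound 1 to compound 2 (0.28 log units; that floor lies within the scatter) and an at least 1.9-fold higher number from compound 1 to compound 3 (0.28 log units; that floor lies within the scatter) both run from a measured number to a limit; the step that the two limits leave unreadable from compound 2 to compound 3 stays unreadable because both ends rest on (the limit of > 50000 nM in this assay, at which 2 of the 3 values shown sit).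

Compound 4 `O=[N+]([O-])c1ccc(Nc2nc(SCc3ccc(C(F)(F)F)cc3)nc3ccccc23)cc1` is not yet measured. It differs from compound 3 by 4-nitrophenyl in place of 2-ethoxyphenyl on a nitrogen on an aromatic ring. For the measured compounds named here, both aryl-bearing compounds seen so far sit at the limit, and no measured step tells how a nitro-bearing ring behaves. The estimated step is a number no higher from compound 3 to compound 4 (the limit leaves the size open). Compound 4 is therefore expected near 50000 nM, within a range from 15000 nM to 200000 nM, with a real chance that this assay again returns only a limit.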

Compound 4, half-maximal inhibitory concentration: 17900 nM
The estimate for compound 4 lay 2.8-fold (0.45 log units) above the measured number; the measured number falls inside the stated range.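

In this assay, an aromatic ring on this nitrogen need not end at the limit: 4-nitrophenyl in place of 2-ethoxyphenyl gives an at least 2.7-fold lower number from compound 3 to compound 4 (0.44 log units; beyond the scatter) and in place of 2-methoxyphenyl gives an at least 2.7-fold lower number from compound 2 to compound 4 (0.44 log units; beyond the scatter). Both steps are floors and not full sizes, because compound 2 and compound 3 each rest on a limit: the limit of > 50000 nM in this assay, at which 2 of the 4 values shown sit. Set against the octyl chain, 4-nitrophenyl shows a 1.5-fold lower number from compound 1 to compound 4 (0.16 log units; within the scatter) and so no real difference between the two groups.

Still open, on these data alone, is whether the lower number goes with the nitro group itself or with its place on the ring, as 4-nitrophenyl differs from 2-ethoxyphenyl in both. Also open, as far as these compounds go, is how a ring carrying an amine or a carboxylic acid in place of the nitro group would read on this nitrogen.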